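Same Side-Chain Swap Carried onto a Second Core

The source may hold more compounds than are shown below. What is called first, only, known or untested is meant among the compounds shown, and "the series" means these compounds.

Measured so far:
compound 1, `Cc1cc(C)cc(S(=O)(=O)c2c(C(=O)NCc3ccccc3)[nH]c3ccc(Br)cc23)c1`: 172000 nM
compound 2, `Cc1cc(C)cc(S(=O)(=O)c2c(C(=O)NCCOc3ccccc3)[nH]c3ccc(Br)cc23)c1`: > 500000 nM
compound 3, `Cc1cc(C)cc(S(=O)(=O)c2c(C(=O)NCCOc3ccccc3)[nH]c3ccc(Cl)c(F)c23)c1`: 11000 nM

In an ADME assay on CCRF-CEM cells (Homo sapiens) for cytotoxicity, read by cell counting (a higher number here means that more compound is tolerated, a lower number that less compound is tolerated), compound 1 gives 172000 nM. For compound 2 the result is a limit of the assay, not a number: > 500000 nM, that is the limit of > 500000 nM in this assay, at which 1 of the 3 values shown sits. Compound 3 gives 11000 nM in this assay.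

Between compound 2 and compound 1 the change is phenyl in place of phenoxymethyl on a saturated chain carbon bound to an amide-type nitrogen, and it made a step of an at least 2.9-fold lower number from compound 2 to compound 1 (0.46 log units; beyond the scatter).

Compound 4, `Cc1cc(C)cc(S(=O)(=O)c2c(C(=O)NCc3ccccc3)[nH]c3ccc(Cl)c(F)c23)c1`, carries the same change on the core of compound 3: phenyl in place of phenoxymethyl on a saturated chain carbon bound to an amide-type nitrogen. How the core of compound 3 differs from that of compound 2 is not broken down here.

Compound 4 is expected to show a step of a 2.8-fold lower number from compound 3 to compound 4 (0.44 log units; beyond the scatter), resting on the step of an at least 2.9-fold lower number from compound 2 to compound 1 (0.46 log units; beyond the scatter), so the estimate for compound 4 in this assay is 4000 nM, likely between 1500 nM and 12000 nM.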

Compound 4, half-maximal cytotoxic concentration: 15000 nM
Estimate against measurement, compound 4: 3.8-fold (0.57 log units) below, and the stated range ends below it.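

On the core of compound 3, the swap of 2-phenoxyethyl to benzyl gives a 1.4-fold higher number from compound 3 to compound 4 (0.13 log units; within the scatter) in this assay, so the change does not carry over from one core to the other with the same effect: the same change on two cores in this assay, an at least 2.9-fold lower number (0.46 log units; beyond the scatter) from compound 2 to compound 1 and a 1.4-fold higher number (0.13 log units; within the scatter) from compound 3 to compound 4, at least 3.9-fold (0.59 log units) apart, beyond the scatter of two such steps

Compound 2 gives > 500000 nM, which is a limit of the assay and not a number. These two pairs do not show which part of the core sets the different outcome, nor how the change would behave on any further core.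

Still open, going by these compounds, is whether the bromine or the chlorine and fluorine on the cores accounts for the gap. Also open, on these data alone, is how a longer chain ending in phenyl, or one ending in an amine, would read in this assay.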